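A few compounds are considered here, and "the series" means these few. Any claim that something is new, unique, unknown or untested is made for them only; others in the source may bear on it.

For the measured compounds named here, compound 1, `C=CCCCCCCCC#CC#C/C=C\C(C)=O`, is the one compound in this set for which a functional assay on SK-MEL-2 cells (Homo sapiens) for cytotoxicity (a lower number here means that less compound is needed, a higher number that more compound is needed for the effect), returns a number: compound 1 gives 43.1 ug/mL. Compound 2, `CCCCCCCC#CC#CC1=CC(=O)NCCC1`, stands differently. For compound 2 this assay reports only a limit, > 50 ug/mL, and that limit is the point (the limit of > 50 ug/mL in this assay, at which 1 of the 2 values shown sits). Of the two values shown, then, one is a number and the other is a limit, so nothing about the size of any step between measured compounds can be read from them, and compound 1 is placed only by its own number.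

The account follows the step from compound 1 to compound 3, `C=CCCCCCCCC#CC#C/C=C/C(C)=O`. The change is the two compounds have the same atoms and bonds and differ only in configuration as drawn: 1 of 1 stereo elements differ; a double bond is drawn Z in compound 1 and E in compound 3. Nothing in the measured pair speaks to what such a change does in this assay. With the chain, the diyne and the carbonyl all kept, a step no larger than the usual scatter is expected, and in either direction. Compound 3 is therefore estimated at 40 ug/mL, with a range from 20 ug/mL to 80 ug/mL, which corresponds to an expected step of a 1.1-fold lower number from compound 1 to compound 3 (0.03 log units; within the scatter).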

Compound 3, concentration for half-maximal effect: 1.5 ug/mL
Compound 3: the middle estimate sits 27-fold (1.43 log units) above what was measured; the measured number lies below the stated range.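

The configuration of this one double bond proves decisive in this assay: going from Z to E gives a 29-fold lower number from compound 1 to compound 3 (1.46 log units; beyond the scatter). The size of that step can be laid to configuration alone, since the chain, the diyne and the carbonyl all stay as they were: the fact that compounds 1 and 3 differ only in the configuration as drawn. Where the earlier compounds offered one number and one limit and so no step at all, this pair gives the first readable step, and it shows that this double bond is a place where the read-out responds strongly to a change that adds and removes no atoms.

What the compounds shown leave open is whether the advantage of the E form holds beyond this single pair, on other chains or with other end groups, and by what means the configuration acts, since one pair cannot tell. Nor can they say whether a carboxylic acid or an amine in place of the carbonyl, or a longer chain, would keep the low number of compound 3.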